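The source may report more compounds than this note shows. Statements on the series, on what has been measured and on what is new or still open speak of the compounds shown alone.

Compound 2, with the structure `CC[C@@H](C)[C@H](NC(=O)c1ccc(Oc2nc3ccccc3nc2C)cc1)C(=O)O`, compound 1, with the structure `Cc1nc2ccccc2nc1Oc1ccc(C(=O)N[C@@H](CC(C)C)C(=O)O)cc1`, and compound 3, with the structure `CC[C@@H](C)[C@H](NC(=O)c1ccc(Oc2nc3ccccc3nc2NC(C)(C)C)cc1)C(=O)O`, were each tested in a functional assay on MCF7 cells (Homo sapiens) for antiproliferative activity, read by MTT assay, with a stated time of 48 h; a lower number here means a stronger inhibitor, a higher number a weaker inhibitor. Compound 2 gives 35700 nM. Compound 1 gives 14700 nM, and compound 3 gives 11400 nM. Compound 1 differs from compound 2 by one change, (isobutyl in place of sec-butyl on a saturated chain carbon bound to an amide-type nitrogen and a carbonyl carbon), and that change brought a 2.4-fold lower number from compound 2 to compound 1 (0.39 log units; beyond the scatter). Compound 3 differs from compound 2 in its core, the change being ((tert-butyl)amino in place of methyl on an aromatic carbon), and that brought a 3.1-fold lower number from compound 2 to compound 3 (0.50 log units; beyond the scatter). The values of compound 3 and compound 1 lie within the scatter of each other, so no order can be read between them.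

Compound 4, with the structure `CC(C)C[C@H](NC(=O)c1ccc(Oc2nc3ccccc3nc2NC(C)(C)C)cc1)C(=O)O`, has not yet been measured in this assay . It differs from compound 3 by isobutyl in place of sec-butyl on a saturated chain carbon bound to an amide-type nitrogen and a carbonyl carbon. This is the same change, at a place described in the same words, as the one between compound 2 and compound 1; among these compounds it occurs twice, once measured and once not. The expectation for compound 4 rests on compound 1, whose step a 2.4-fold lower number from compound 2 to compound 1 (0.39 log units; beyond the scatter) is the only measured instance of this change, and on the fact that the core of compound 3 differs from that of compound 2 as described above, which leaves open whether the change carries over in full. A step of similar size is expected, with some allowance for the different core. Compound 4 is therefore estimated to give about 5500 nM in this assay , most likely between 2500 nM and 12000 nM. That estimate means an expected step of a 2.1-fold lower number from compound 3 to compound 4 (0.32 log units; beyond the scatter).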

Compound 4, half-maximal inhibitory concentration: 40300 nM
Compound 4: middle estimate off by 7.3-fold (0.86 log units), on the low side; the whole stated range lies below it.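

In this assay, putting isobutyl in place of sec-butyl did not act the same way on the two cores. On the core of compound 3 it gave a 3.5-fold higher number from compound 3 to compound 4 (0.55 log units; beyond the scatter), opposite in direction to the earlier step, so the step measured on the first core did not carry over: the same change on two cores in this assay, a 2.4-fold lower number (0.39 log units; beyond the scatter) from compound 2 to compound 1 and a 3.5-fold higher number (0.55 log units; beyond the scatter) from compound 3 to compound 4, 8.6-fold (0.93 log units) apart, beyond the scatter of two such steps

The same mismatch appears from the other side, where (tert-butyl)amino in place of methyl on an aromatic carbon gave a 2.7-fold higher number from compound 1 to compound 4 (0.44 log units; beyond the scatter), while the same swap with sec-butyl in the molecule had lowered the number: the same change on two cores in this assay, a 3.1-fold lower number (0.50 log units; beyond the scatter) from compound 2 to compound 3 and a 2.7-fold higher number (0.44 log units; beyond the scatter) from compound 1 to compound 4, 8.6-fold (0.93 log units) apart, beyond the scatter of two such steps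

This shows that, for these four compounds, each change has an effect that depends on the other, so neither step can simply be added to a new compound, but it does not show why the direction flips, nor whether the same would happen elsewhere in the series, since it rests on a single set of four compounds.

Going by these compounds, it remains open whether a similar reversal would appear with other groups on the saturated chain carbon, such as isopropyl or benzyl. On these data alone, it is equally open whether a plain amine or an ethyl group on the aromatic carbon would pair with isobutyl and sec-butyl in the same way.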